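Working notes on compound 4 of the aminothiazole series

The compounds below may be only part of what the source reports. "The series", "measured", "known", "first", "only" and "open" are said of these compounds alone.

Measured so far in a functional assay on Right cardiac atrium for agonist activity at histamine H2 receptor (Cavia porcellus), with a stated time of 30 min, in the presence of a further agent that is not named here; a higher number here means that more compound is needed for the effect, a lower number that less compound is needed:

compound 1 `Cc1nc(N)sc1CCCN/C(N)=N/C(=O)NC(C)c1ccc(Br)cc1` gives 55 nM
compound 2 `Cc1nc(N)sc1CCCN/C(N)=N/C(=O)NC(c1ccccc1)c1ccccc1` gives 39.8 nM
compound 3 `Cc1nc(N)sc1CCCN/C(N)=N/C(=O)NC(C)c1ccc(OC(F)(F)F)cc1` gives 724 nM

Compound 1 stands second highest of the three numbers. Compound 2 lies within the scatter of compound 1, so no order between the two can be read. Within the data shown here, compound 3 stands apart: the single measured step is a 13-fold higher number from compound 1 to compound 3 (1.12 log units; beyond the scatter), and it shows that a change on the aromatic ring attached to the saturated chain carbon can move the number well beyond the scatter.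

Compound 4 `Cc1nc(N)sc1CCCN/C(N)=N/C(=O)NC(C)c1ccco1` is not yet measured. It differs from compound 1 thus: furan-2-yl in place of 4-bromophenyl on a saturated chain carbon bound to an amide-type nitrogen and a saturated chain carbon. Among the measured compounds shown here, no measured step swaps the whole ring at this position; the step from compound 1 to compound 3 kept the six-membered ring and altered only its substituent, so it bears on the present change only loosely, as a sign that this region is sensitive. Compound 2 shows that a bulkier group at the same carbon does not raise the number.

The expectation for compound 4 in this assay is therefore a moderate rise, a 2.7-fold higher number from compound 1 to compound 4 (0.44 log units; beyond the scatter), smaller than the step to compound 3. Compound 4 is estimated at 150 nM, with a range from 50 nM to 500 nM.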

Compound 4, half-maximal effective concentration: 9.77 nM
Compound 4: the middle estimate sits 15-fold (1.19 log units) above what was measured, outside the stated range (below it).
By their numbers in this assay, from the lowest: compound 4; then compounds 2 and 1 (each within the scatter of the next); then compound 3.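

In this assay, exchanging the whole ring at this saturated chain carbon gives a 5.6-fold lower number from compound 1 to compound 4 (0.75 log units; beyond the scatter) and so lowers the number, which the earlier substituent change on the six-membered ring gave no sign of. A six-membered aromatic ring of carbon only is therefore not needed at this position for a low number, since furan-2-yl, a five-membered aromatic ring with 1 hetero atom, serves here in place of 4-bromophenyl. Set beside a 13-fold higher number from compound 1 to compound 3 (1.12 log units; beyond the scatter), the new step shows that changes at this end of the molecule can move the number beyond the scatter in either direction from compound 1, not only upward.

The compounds shown leave open whether the same holds for other five-membered rings such as thiophen-2-yl or furan-3-yl, and whether a plain phenyl ring on the same carbon would stand nearer to compound 1 or to compound 4. Nothing here separates the contributions of ring size, the ring oxygen and the loss of the bromine, and no supporting measurement bears on the reason for the step.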